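The source may hold more compounds than are shown below. What is called first, only, known or untested is meant among the compounds shown, and "the series" means these compounds.

Compound 1 `CC(C)CCc1ccc2c(NCCCNCc3ccco3)ccnc2c1` was tested in a physicochemical assay for solubility, with a stated time of 18 h, at pH 7.4 (on this read-out lower numbers stand for lower solubility and higher numbers for higher solubility), where compound 1 gives 4200 nM. Compound 2 `COc1ccc(F)cc1CNCCCNc1ccnc2cc(CCC(C)C)ccc12` gives 4200 nM, and the step of no change at the digits printed from compound 1 to compound 2 (within the scatter) stays within the scatter, so compound 1 stands level with compound 2 at the digits shown. Compound 3 `COc1ccc(Oc2ccc3c(NCCCNCc4ccco4)ccnc3c2)cc1` differs from compound 1 by 4-methoxyphenoxy in place of isopentyl on an aromatic carbon. Among the compounds with values here, no measured step touches this aromatic carbon; the single known step altered a different part of the molecule and moved nothing. Within the data shown here, with no step bearing on it, the expected change a 1.2-fold higher number from compound 1 to compound 3 (0.08 log units; within the scatter) is small and without a clear direction. Compound 3 is estimated at 5000 nM, within 1500 nM to 15000 nM.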

Compound 3, solubility: 14500 nM
For compound 3 the middle estimate is 2.9-fold (0.46 log units) below the measured one; measured number inside the range.
By their numbers in this assay, from the lowest: compounds 1 and 2 (each within the scatter of the next); then compound 3.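

Within the data shown here, the aromatic carbon carrying isopentyl in compound 1 can shift the number in this assay, since 4-methoxyphenoxy there gives a 3.5-fold higher number from compound 1 to compound 3 (0.54 log units; beyond the scatter) and so moves beyond the scatter, unlike the one earlier step, made elsewhere in the molecule. Nothing available explains this rise. The swap changes several things at once, adding an aromatic ring and two oxygens, so this single step cannot show which of them matters. Going by these compounds, whether a plain phenoxy or a carboxylic acid at this carbon would give a similar number remains open, as does whether the step holds with 5-fluoro-2-methoxyphenyl in place of furan-2-yl.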